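Furanyl for cyanophenyl on a furan-ether biaryl acid

The compounds below may be only part of what the source reports. "The series", "measured", "known", "first", "only" and "open" are said of these compounds alone.

Compound 1 `Cc1oc(C(=O)O)cc1COc1ccc(-c2ccc(C#N)cc2)cc1` gives 1500 nM in an assay on cells for displacement of a labelled ligand from prostaglandin E2 receptor EP4 subtype (Homo sapiens), read by scintillation counting (on this read-out higher numbers stand for weaker inhibition and lower numbers for stronger inhibition), the highest of the two numbers recorded. Compound 2 `Cc1oc(CC(=O)O)cc1COc1ccc(-c2ccccc2)cc1`, which carries a different acid chain and a plain phenyl, gives 80 nM in this assay. Compound 3 `Cc1oc(C(=O)O)cc1COc1ccc(-c2ccoc2)cc1` is not yet measured; it differs from compound 1 by furan-3-yl in place of 4-cyanophenyl on an aromatic carbon. Among the compounds with values here, no single-change step is available, so the direction is open; the smaller ring is expected to leave binding roughly where it was or somewhat weaker, a step of a 1.3-fold higher number from compound 1 to compound 3 (0.12 log units; within the scatter). Compound 3 is therefore estimated at 2000 nM, within 500 nM to 8000 nM.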

Compound 3, inhibition constant: > 10000 nM
Compound 3 gave a limit, no number (the forecaster's own chance of this, stated with the estimate: 15%); middle value at least 5.0-fold (0.69 log units) away from the limit.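

In this assay compound 3 gives a limit of the assay, not a number: the limit of > 10000 nM in this assay, at which 1 of the 3 values shown sits. Even so, the first single-change step at this position can be read as an at least 6.6-fold higher number from compound 1 to compound 3 (0.82 log units; beyond the scatter), so furan-3-yl does not stand in for 4-cyanophenyl here, and the group on this aromatic carbon, para to a large group, matters for binding on the shared core.

From the compounds shown here alone, how far binding falls past the limit stays open. So does whether a plain phenyl, or an amine or methoxy group in place of the nitrile, would hold binding on this acid, since compound 2 differs in more than one place.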